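A benzyl-to-aryl swap on the sulfonamide nitrogen

A few compounds are considered here, and "the series" means these few. Any claim that something is new, unique, unknown or untested is made for them only; others in the source may bear on it.

Compound 1, with the structure `O=C(Nc1ccc(S(=O)(=O)NCc2ccccc2)cc1)c1ccc(Cl)cc1Cl`, sits at the edge of what a functional assay on HEK293 cells for agonist activity at probable G-protein coupled receptor 27 (Homo sapiens), read by a luciferase reporter and beta-arrestin recruitment, with a stated time of 10 min (on this read-out higher numbers stand for an effect only at larger amounts of compound and lower numbers for an effect already at smaller amounts), can report: its value of > 100000 nM is a limit of the assay, not a number (the limit of > 100000 nM in this assay, at which 1 of the 3 values shown sits). Two related compounds carry a phenyl group on the sulfonamide nitrogen instead of a benzyl group. Compound 2, `O=C(Nc1ccc(S(=O)(=O)Nc2ccccc2)cc1)c1ccc(Cl)cc1F`, gives 3980 nM in this assay. Compound 3, `O=C(Nc1ccc(S(=O)(=O)Nc2ccccc2)cc1)c1cc(F)c(Cl)cc1F`, gives 141 nM in this assay, and the measured step of a 28-fold lower number from compound 2 to compound 3 (1.45 log units; beyond the scatter) shows how much a single fluoro in place of hydrogen on an aromatic carbon can move the number.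

Compound 4, `Cc1ccccc1NS(=O)(=O)c1ccc(NC(=O)c2ccc(Cl)cc2Cl)cc1`, differs from compound 1 by 2-methylphenyl in place of benzyl on a sulfonamide nitrogen. Among the compounds with values here, no measured step covers this exact change; what the data show is that the compounds with an aryl group on the sulfonamide nitrogen, compound 2 and compound 3, give numbers rather than limits. Compound 4 is therefore expected to land in this assay near the value of compound 2, with the step of an at least 20-fold lower number from compound 1 to compound 4 (1.30 log units; beyond the scatter) meaning a move from the limit down into the measurable range. The estimate for compound 4 in this assay is 5000 nM, between 500 nM and 60000 nM.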

Compound 4, half-maximal effective concentration: 1230 nM
Compound 4: the middle estimate sits 4.1-fold (0.61 log units) above what was measured, within the range that was stated.
By their numbers in this assay, from the lowest: compound 3; then compound 4; then compound 2. At a limit, above all of these: compound 1.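

In this assay, within the data shown here, 2-methylphenyl in place of benzyl on a sulfonamide nitrogen gives an at least 81-fold lower number from compound 1 to compound 4 (1.91 log units; beyond the scatter), which is the first direct measure of a change at this place with the rest of the molecule held the same. Both groups hold the same count of carbon atoms and one aromatic ring, so the same atoms, joined differently, are enough to bring the number into the measurable range. Compound 1 stands at a limit, so this step gives only the smallest size the change can have: the limit of > 100000 nM in this assay, at which 1 of the 4 values shown sits.

On these data alone, how much of the step belongs to the methyl group remains open, and a plain phenyl on this same core would help to separate the two. Also open, as far as these compounds go, is how a longer chain such as 2-phenylethyl on the sulfonamide nitrogen, or an amine or a carboxylic acid on its ring, would read.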